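One group exchanged on compound 3

The source may report more compounds than this note shows. Statements on the series, on what has been measured and on what is new or still open speak of the compounds shown alone.

Measured in a functional assay on COR-L23 cells (Homo sapiens) for antiproliferative activity, read by CellTiter-Glo, with a stated time of 72 h; a lower number here means a stronger inhibitor, a higher number a weaker inhibitor:
Compound 1 `O=C(Nc1ccc(CN2Cc3ccccc3C2=O)cc1)N1CC(c2cccnc2)C1` gives 9.9 nM
Compound 2 `O=C(Nc1ccc(CN2Cc3ccccc3C2=O)cc1)N1CCC(c2cccnc2)C1` gives > 2500 nM; > 2500 nM (2 entries), which is a limit of the assay and not a number
Compound 3 `C[C@@H](c1ccc(NC(=O)N2CC(c3cccnc3)C2)cc1)N1Cc2ccccc2C1=O` gives 8 nM

Compound 3 stands at 8 nM in this assay. Its nearest neighbour is compound 1 at 9.9 nM, and the two lie within the usual scatter of each other. Together they carry the only true numbers in this small set.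

The next molecule is compound 4 `C[C@H](NC(=O)c1cccc(F)c1)c1ccc(NC(=O)N2CC(c3cccnc3)C2)cc1`, which changes one part of compound 3: a group of 10 heavy atoms (7 carbon, 1 nitrogen, 1 oxygen, 1 fluorine; one six-membered aromatic ring of carbon only) in place of a group of 10 heavy atoms (8 carbon, 1 nitrogen, 1 oxygen; one five-membered non-aromatic ring with 1 hetero atom, one six-membered aromatic ring of carbon only), on a saturated chain carbon bound to an aromatic carbon and a saturated chain carbon. The group that enters is called ((3-fluorophenyl)carbonyl)amino.

Within the data shown here, only one measured step offers any guide, and it is a 1.2-fold lower number from compound 1 to compound 3 (0.09 log units; within the scatter). That step added a methyl and left the number within the scatter, but it did not replace the group that now changes. Among the measured compounds shown here, no measured compound makes this exchange, so the guidance is indirect. A modest rise in the number is expected in this assay, with wide uncertainty in both directions. The estimate corresponds to a 2.3-fold higher number from compound 3 to compound 4 (0.35 log units; beyond the scatter), an expected step that may not clearly exceed the scatter. For compound 4 the estimated value is 18 nM, with an expected range from 4 nM to 90 nM.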

Compound 4, half-maximal inhibitory concentration: 10 nM
Compound 4: middle estimate off by 1.8-fold (0.26 log units), on the high side; the measured number falls inside the stated range.
By their numbers in this assay, from the lowest: compounds 3, 1 and 4 (each within the scatter of the next).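

In this assay the exchange gives a 1.3-fold higher number from compound 3 to compound 4 (0.10 log units; within the scatter), so this step lies within the scatter. The earlier step added only a methyl, whereas this one shows that the whole group on a saturated chain carbon bound to an aromatic carbon and a saturated chain carbon can be replaced without the number moving beyond the scatter. The five-membered non-aromatic ring is gone in compound 4, and the group that enters, ((3-fluorophenyl)carbonyl)amino, has 1 hydrogen-bond donor where the group that leaves has 0, yet no measurement shown here explains why the two groups give numbers so alike.

The compounds shown leave open whether the fluorine matters at all, a question that the same group with hydrogen in place of fluorine would address. They also leave open how far this position accepts other kinds of group, such as a plain amine, a carboxylic acid or a longer chain, so the match between compound 3 and compound 4 cannot yet be read as a general rule for this position.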